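Swapping the Heteroaryl on Sulfur Near the Assay Ceiling

A few compounds are considered here, and "the series" means these few. Any claim that something is new, unique, unknown or untested is made for them only; others in the source may bear on it.

Compound 3 `Cc1nnc(SCC(=O)[C@H](CC(=O)O)NC(=O)[C@@H](NC(=O)COc2cccc3ccccc23)C(C)C)s1` is the only one of the three measured compounds that returns a number in a functional assay on Jurkat cells (Homo sapiens) for inhibition (on this read-out lower numbers stand for stronger inhibition and higher numbers for weaker inhibition), where compound 3 gives 190000 nM. Compound 1 `CC(C)[C@H](NC(=O)COc1cccc2ccccc12)C(=O)N[C@@H](CC(=O)O)C(=O)CSc1nc(-c2ccccc2)cs1` reaches only the limit of this assay; in this assay compound 1 gives > 200000 nM. Compound 2 `CC(C)[C@H](NC(=O)COc1cccc2ccccc12)C(=O)N[C@@H](CC(=O)O)C(=O)CSc1nc[nH]n1` also sits at that limit; in this assay compound 2 gives > 200000 nM. All three share one core and differ only in the aromatic ring attached to the sulfur. The step of an at least 1.0-fold lower number from compound 1 to compound 3 (0.02 log units; that floor lies within the scatter) and the step of an at least 1.0-fold lower number from compound 2 to compound 3 (0.02 log units; that floor lies within the scatter) are both floors lying within the scatter, and the step that the two limits leave unreadable from compound 1 to compound 2 cannot be read, so no exchange of this ring among these three compounds has produced a change that can be trusted; the limit of > 200000 nM in this assay, at which 2 of the 3 values shown sit, frames that picture.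

Compound 4 `CC(C)[C@H](NC(=O)COc1cccc2ccccc12)C(=O)N[C@@H](CC(=O)O)C(=O)CSc1nc2ccccc2s1` carries the change (1,3-benzothiazol-2-yl in place of 5-methyl-1,3,4-thiadiazol-2-yl on a sulfur). Among the compounds with values here, the steps that bear on it are the two leading to compound 3, neither of which shows a readable change. So for compound 4 a step of no readable size is expected in this assay, a 1.1-fold higher number from compound 3 to compound 4 (0.02 log units; within the scatter), with a fair chance that only the limit is reported. Compound 4 is therefore estimated at 200000 nM in this assay, in a range from 90000 nM to 450000 nM.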

Compound 4, half-maximal inhibitory concentration: > 200000 nM
Compound 4 gave a limit, no number; the forecaster's own chance of this, stated with the estimate: 60%; the middle value lies on the limit itself.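

Placing 1,3-benzothiazol-2-yl on the sulfur adds a six-membered aromatic ring of carbon only to the group there, and in this assay the exchange gives an at least 1.0-fold higher number from compound 3 to compound 4 (0.02 log units; that floor lies within the scatter). So even this larger change of the group, with two aromatic rings in place of one, brings no shift that can be trusted. The steps to compound 4 from compound 1 and from compound 2 join one limit to another and cannot be read, and the series now sits almost entirely at the ceiling of the read-out: the limit of > 200000 nM in this assay, at which 3 of the 4 values shown sit.

Still open, from the compounds shown here alone, is whether a group of another kind on this sulfur, such as a plain ethyl chain or a chain ending in an amine, would give a number clearly lower than that of compound 3. Also open, going by these compounds, is whether the group on the sulfur matters at all for inhibition in these cells, as results this close to the limit cannot tell a small effect from none.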